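Ring Enlargement on the Amine Tail of Compound 1

A few compounds are considered here, and "the series" means these few. Any claim that something is new, unique, unknown or untested is made for them only; others in the source may bear on it.

Compound 1 `COc1cc2c(Nc3ccc(C#N)cc3)ncnc2cc1OCCCN1CCCC1` carries a pyrrolidin-1-yl on a saturated chain carbon, three bonds along the chain from an oxygen on an aromatic ring. Among the measured compounds shown here, in a functional assay on A549 cells (Homo sapiens) for antiproliferative activity, read by MTT assay, with a stated time of 72 h (a higher number here means a weaker inhibitor, a lower number a stronger inhibitor), compound 1 gives 21800 nM, the only plain number among the values shown. Compound 2 `COc1cc2c(Nc3ccc(C#N)cc3)ncnc2cc1OCCCN1CCCCC1CCO` differs only in that amine. In this assay compound 2 reaches only a limit of the assay, > 100000 nM, as recorded in the limit of > 100000 nM in this assay, at which 1 of the 2 values shown sits. The step of an at least 4.5-fold higher number from compound 1 to compound 2 (0.66 log units; beyond the scatter) runs toward weaker inhibition. Compound 3 `COc1cc2c(Nc3ccc(C#N)cc3)ncnc2cc1OCCCN1CCC(c2ccccc2)CC1` makes a related change: 4-phenylpiperidin-1-yl in place of pyrrolidin-1-yl on a saturated chain carbon, three bonds along the chain from an oxygen on an aromatic ring. For the measured compounds named here, the only measured step that bears on it is the one to compound 2, at least modest and toward a higher number, so a step in the same direction is expected, a 2.3-fold higher number from compound 1 to compound 3 (0.36 log units; beyond the scatter). Compound 3 is therefore estimated at 50000 nM in this assay, with a range from 15000 nM to 150000 nM, and a real chance that only a limit is reported.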

Compound 3, half-maximal inhibitory concentration: 9500 nM
For compound 3 the middle estimate is 5.3-fold (0.72 log units) above the measured one, outside the stated range (below it).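

In this assay, a larger amine at this place does not have to cost activity: 4-phenylpiperidin-1-yl goes the opposite way to 2-(2-hydroxyethyl)piperidin-1-yl, with a 2.3-fold lower number from compound 1 to compound 3 (0.36 log units; beyond the scatter) on this change. What is attached to the six-membered ring therefore counts for much here, with an at least 10-fold lower number from compound 2 to compound 3 (1.02 log units; beyond the scatter) between the two enlarged amines. That step starts from a limit of the assay and not from a number, and compound 2 is recorded only as such: the limit of > 100000 nM in this assay, at which 1 of the 3 values shown sits.

Going by these compounds, whether the six-membered ring or the phenyl ring carries the gain over pyrrolidin-1-yl remains open, and plain piperidin-1-yl would separate the two. Also open, on these data alone, is how 4-(2-hydroxyethyl)piperidin-1-yl, morpholin-4-yl or a longer chain would read at this place.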